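One Ring Swapped, One Chloro Returned

This account rests on a few compounds, and the source may have more. Where it says the series, first, only, none or still open, it means among the compounds named here.

Compound 2: `COc1cc(CSc2cc(Cl)c(-c3nnc(-c4ccccc4)s3)cc2S(=O)(=O)NC(=N)NO)cc(OC)c1OC` gives 3240 nM
Compound 1: `COc1cc(CSc2cc(Cl)c(-c3nnc(-c4ccc(Cl)cc4)s3)cc2S(=O)(=O)NC(=N)NO)cc(OC)c1OC` gives 34700 nM

Going by the values given here, in a functional assay on NCI-H460 cells (Homo sapiens) (on this read-out higher numbers stand for weaker inhibition of growth and lower numbers for stronger inhibition of growth), compound 2 has the lowest of the two numbers measured so far; compound 1 sits far above it, with an 11-fold lower number from compound 1 to compound 2 (1.03 log units; beyond the scatter) separating them. Compound 3, `COc1cc(CSc2cc(Cl)c(-c3nc(-c4ccc(Cl)cc4)no3)cc2S(=O)(=O)NC(=N)NO)cc(OC)c1OC`, carries 3-(4-chlorophenyl)-1,2,4-oxadiazol-5-yl in place of 5-phenyl-1,3,4-thiadiazol-2-yl on an aromatic carbon. Among the compounds with values here, only one measured step bears on this change, and only in part: an 11-fold lower number from compound 1 to compound 2 (1.03 log units; beyond the scatter) shows that taking the chloro off that ring lowered the number by a large amount, so putting it back on compound 3 is expected to raise it again. Within the data shown here, the exchange of the five-membered ring has no measured counterpart here, so its effect is unknown and widens the range. On balance, the step of a 4.6-fold higher number from compound 2 to compound 3 (0.67 log units; beyond the scatter) is expected to be upward in this assay. Compound 3 is therefore estimated at 15000 nM, with a range from 3000 nM to 70000 nM.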

Compound 3, concentration for 50% growth inhibition: 2240 nM
Beside the measured number, compound 3's estimate is 6.7-fold (0.83 log units) above it; the whole stated range lies above it.
By their numbers in this assay, from the lowest: compounds 3 and 2 (each within the scatter of the next); then compound 1.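

In this assay, holding the 4-chlorophenyl ring and changing only the five-membered ring gives a 15-fold lower number from compound 1 to compound 3 (1.19 log units; beyond the scatter), so the ring that joins this group to the core can matter a great deal. The chloro therefore does not bring a high number wherever it appears: compound 3 carries it, yet the exchange for the 5-phenyl-1,3,4-thiadiazol-2-yl group gives a 1.4-fold lower number from compound 2 to compound 3 (0.16 log units; within the scatter). Nothing at hand explains why the five-membered ring makes this difference.

The compounds shown leave open what the chloro itself contributes within the 3-(4-chlorophenyl)-1,2,4-oxadiazol-5-yl group. They also leave open whether a methoxy group or an amine in the chloro's place would give a number close to that of compound 3.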